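The compounds below may be only part of what the source reports. "The series", "measured", "known", "first", "only" and "open" are said of these compounds alone.

In a functional assay on MCF7 cells (Homo sapiens) for antiproliferative activity, read by MTT assay (on this read-out lower numbers stand for stronger inhibition and higher numbers for weaker inhibition), compound 1 `NS(=O)(=O)c1ccc(C(=O)N/N=C(/CS(=O)(=O)c2ccccc2)c2ccc(F)cc2)cc1` gives 620 nM and compound 2 `C/C(=N/NC(=O)c1ccc(S(N)(=O)=O)cc1)c1ccc(Br)cc1` gives 2290 nM. Compound 2 therefore holds the higher of the two numbers, and the gap between them lies beyond the usual scatter. Compound 3 `C/C(=N/NC(=O)c1ccc(S(N)(=O)=O)cc1)c1ccc(F)cc1` alters compound 2 in one place: fluoro in place of bromo on an aromatic carbon. Among the measured compounds shown here, no measured pair shows this swap, so no step beyond the scatter is expected, with at most a slight drift toward a lower number. The estimated change is a 1.2-fold lower number from compound 2 to compound 3 (0.08 log units; within the scatter). For compound 3 the expected value is 1900 nM, within an estimated range of 700 nM to 5500 nM.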

Compound 3, half-maximal inhibitory concentration: 31900 nM
For compound 3 the middle estimate is 17-fold (1.23 log units) below the measured one; the measured number lies above the stated range.
By their numbers in this assay, from the lowest: compound 1; then compound 2; then compound 3.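

In this assay there is a 14-fold higher number from compound 2 to compound 3 (1.14 log units; beyond the scatter) with fluoro in place of bromo, para to a large group, so exchanging this one heavy atom on the aromatic ring can move the number far. With the 4-fluorophenyl kept, hydrogen in place of phenylsulfonyl on the chain gives a 51-fold higher number from compound 1 to compound 3 (1.71 log units; beyond the scatter) and shows that this chain substituent also weighs heavily. No measurement at hand accounts for either step. Open, as far as these compounds go, is where chloro or methyl would fall at the ring position, and whether phenylsulfonyl would bring a similar step alongside 4-bromophenyl.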